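The source may hold more compounds than are shown below. What is called first, only, known or untested is meant among the compounds shown, and "the series" means these compounds.

Values in a functional assay on Huh-7 cells (Homo sapiens) for inhibition, read by sulforhodamine B assay, with a stated time of 72 h; on this read-out higher numbers stand for weaker inhibition and lower numbers for stronger inhibition:
Compound 1 `O=C(/C=C/c1cn(-c2ccccc2)nc1-c1cccnc1)c1ccccn1`: 6400 nM
Compound 2 `O=C(/C=C/c1cn(-c2ccccc2)nc1-c1cccnc1)c1c[nH]c2ccccc12`: 3200 nM
Compound 3 `COc1ccc(OC)c(C(=O)/C=C/c2cn(-c3ccccc3)nc2-c2cccnc2)c1`: 1300 nM

Compound 3 gives the lowest number of the three: the steps of a 4.9-fold lower number from compound 1 to compound 3 (0.69 log units; beyond the scatter) and a 2.5-fold lower number from compound 2 to compound 3 (0.39 log units; beyond the scatter) both lie beyond the scatter, while a 2.0-fold lower number from compound 1 to compound 2 (0.30 log units; within the scatter) does not.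

Compound 4 `COc1ccc(OC)c(C(=O)/C=C/c2cn(-c3ccccc3)nc2-c2ccncc2)c1` keeps the carbonyl side of compound 3 and changes only the other end of the shared core: pyridin-4-yl in place of pyridin-3-yl on an aromatic carbon. Going by the values given here, none of the measured steps touches this position; all three concern the group on the carbonyl carbon. Among the compounds with values here, no step therefore gives a size or a direction for this change, and a step within the scatter is the neutral expectation, so the estimate rests on the value of compound 3.

Compound 4 is expected near 1500 nM, with a range of 600 nM to 4000 nM, i.e. an expected step of a 1.2-fold higher number from compound 3 to compound 4 (0.06 log units; within the scatter).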

Compound 4, half-maximal inhibitory concentration: 1700 nM
Estimate against measurement, compound 4: 1.1-fold (0.05 log units) below; the measured number falls inside the stated range.
By their numbers in this assay, from the lowest: compounds 3, 4, 2 and 1 (each within the scatter of the next, the first and the last beyond it).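

In this assay, pyridin-4-yl in place of pyridin-3-yl gives a 1.3-fold higher number from compound 3 to compound 4 (0.12 log units; within the scatter). Going by these compounds alone, this is the first reading at this position, and with 2,5-dimethoxyphenyl on the carbonyl carbon the two pyridine isomers cannot be told apart. No measurement on hand bears on this result. Open, on these data alone, is whether a ring nitrogen is needed here at all, which a plain phenyl or a 4-aminophenyl group at this position would test. Also open, as far as these compounds go, is whether the same holds with 1H-indol-3-yl or pyridin-2-yl on the carbonyl carbon.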